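Removing a Methoxy Group: Expectation at the Assay Limit

The source may hold more compounds than are shown below. What is called first, only, known or untested is meant among the compounds shown, and "the series" means these compounds.

Compound 3, `COc1cccc(Cn2cc(C(O)c3ccc(C)cc3)nn2)c1`, is the point of departure. In a functional assay on B16 cells (Mus musculus) for cytotoxicity, read by MTT assay, with a stated time of 48 h (on this read-out higher numbers stand for weaker inhibition and lower numbers for stronger inhibition), compound 3 gives > 100000 nM, which is a limit of the assay and not a number. The two other measured compounds stand at the same limit. Compound 1, `Cc1ccc(C(O)c2cn(C[C@H]3COC(C)(C)O3)nn2)cc1`, gives in this assay > 100000 nM, again a limit. Compound 2, `Cc1ccc(C(O)c2cn(CC3COC(C)(C)O3)nn2)cc1`, gives in this assay > 100000 nM, also a limit. Among the compounds with values here, the only step between measured compounds, a step that the two limits leave unreadable from compound 1 to compound 2, stays unreadable because of the limit of > 100000 nM in this assay, at which 3 of the 3 values shown sit; the two compounds differ only in that (the fact that one of compounds 1 and 2 is drawn with a defined configuration and the other without, at the place where they differ).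

Compound 4, `Cc1ccc(C(O)c2cn(Cc3ccccc3)nn2)cc1`, differs from compound 3 by hydrogen in place of methoxy on an aromatic carbon. Within the data shown here, no measured step bears on this change; the methoxy group is present in neither compound 1 nor compound 2, so the measured material offers nothing on what its removal does. Among the measured compounds shown here, what the numbers show is simply that every compound measured so far sits at the limit, and there is no measured step of any readable size.

For compound 4 the expectation is therefore a value at the same limit, with no step beyond the scatter. The step that the limit leaves unreadable from compound 3 to compound 4 is expected to be negligible. Compound 4 is estimated at 150000 nM, within 50000 nM to 500000 nM.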

Compound 4, half-maximal inhibitory concentration: > 100000 nM
Compound 4: no number, only a limit; the forecaster's own chance of this, stated with the estimate: 85%; the middle value is on the limit's open side.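

In this assay compound 4 gives > 100000 nM, a limit of the assay and not a number. The steps from compound 1, compound 2 and compound 3 to compound 4 cannot be read, because of one shared fact: the limit of > 100000 nM in this assay, at which 4 of the 4 values shown sit. The compounds shown leave open whether hydrogen in place of methoxy, phenyl in place of 2,2-dimethyl-1,3-dioxolan-4-yl, or a defined configuration makes any difference to the read-out.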